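Chloro to fluoro where only limits are known

The source may hold more compounds than are shown below. What is called first, only, known or untested is meant among the compounds shown, and "the series" means these compounds.

Compound 2 (`CCOC(=O)c1c(-c2cccc(OC)c2)[nH]c2cc(OC)c(Cl)cc2c1=O`) has no exact reading in an ADME assay on BJ cells (Homo sapiens) for cytotoxicity, read by luminescence, with a stated time of 72 h; on this read-out lower numbers stand for an effect already at smaller amounts and higher numbers for an effect only at larger amounts of compound. Compound 2 reads > 21500 nM, which is a limit of the assay. Compound 1 (`CCOC(=O)c1c(-c2cccc(OC)c2)[nH]c2cc(Cl)c(Cl)cc2c1=O`) reads > 21500 nM, also a limit. Compound 3 (`CCOC(=O)c1c(-c2cc(F)cc(OC)c2)[nH]c2cc(OC)c(Cl)cc2c1=O`) reads > 21500 nM, again a limit. The picture so far is the limit of > 21500 nM in this assay, at which 3 of the 3 values shown sit.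

Compound 4 (`CCOC(=O)c1c(-c2cccc(OC)c2)[nH]c2cc(OC)c(F)cc2c1=O`) has not yet been measured. Its difference from compound 2 is fluoro in place of chloro on an aromatic carbon, ortho to a methoxy group.

Among the measured compounds shown here, two measured steps bear on this change. For the measured compounds named here, the first is a step that the two limits leave unreadable from compound 1 to compound 2, with methoxy in place of chloro on an aromatic carbon. The second is a step that the two limits leave unreadable from compound 2 to compound 3, with fluoro in place of hydrogen on an aromatic carbon. Neither has a readable size, yet all three compounds remain at the limit. Going by the values given here, no step of measurable size is therefore expected in this assay, in either direction, and compound 4 is expected to be reported as a limit too. The estimated change is a step that the limit leaves unreadable from compound 2 to compound 4. For compound 4 the estimate is 25000 nM, with an expected range from 14000 nM to 50000 nM.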

Compound 4, half-maximal effective concentration: > 21500 nM
Compound 4 was reported as a limit; the forecaster's own chance of this, stated with the estimate: 85%; the middle value is on the limit's open side.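

In this assay compound 4 gives > 21500 nM, which is a limit of the assay. Compound 2 also stands at a limit, so no step can be read between compound 2 and compound 4. The compounds shown leave open at what concentration, if any, any of them would show an effect, with the picture still resting on one reading: the limit of > 21500 nM in this assay, at which 4 of the 4 values shown sit.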